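Swapping One Aromatic Ring for Another on a Shared Core

The source may report more compounds than this note shows. Statements on the series, on what has been measured and on what is new or still open speak of the compounds shown alone.

Of the compounds shown here, two have so far been measured in a functional assay on the whole organism (serum, strain Swiss albino) with Rattus norvegicus as the target, read by spectrophotometry, with a stated time of 14 days, at a dose of 10 mg/kg by the oral route; a lower number here means less inhibition, a higher number more inhibition at the dose given (going by the name of the read-out). Compound 1 `O=C1c2cc(Cl)c(Cl)cc2C(=O)N1c1ncccn1` gives 58%, the higher of the two numbers. Compound 2 `O=C1c2c(Cl)c(Cl)c(Cl)c(Cl)c2C(=O)N1Cc1ccccn1` gives 47%, and the gap between compound 2 and compound 1 lies beyond the usual scatter of repeated measurements. The two compounds differ in more than one place, so no single measured step can be read from them.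

Compound 3 `O=C1c2cc(Cl)c(Cl)cc2C(=O)N1c1ccncc1` differs from compound 1 by one change only: pyridin-4-yl in place of pyrimidin-2-yl on an amide-type nitrogen in a ring. Going by the values given here, no measured step of this kind exists among the compounds seen here, so the expectation rests on compound 1 alone. The step of a number 3 percentage points lower from compound 1 to compound 3 (within the scatter) is expected to be small, not beyond the scatter, in either direction. Compound 3 is therefore estimated at 55%, within a range from 40% to 70%.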

Compound 3, a percentage reported as inhibition, in the whole organism at one dose (the size of the read-out at that dose, not a potency): 19%
Compound 3: middle estimate off by 36 percentage points, on the high side; measured number below the stated range.
By their numbers in this assay, from the lowest: compound 3; then compound 2; then compound 1.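

In this assay, pyridin-4-yl in place of pyrimidin-2-yl on the amide-type nitrogen in a ring gives a number 39 percentage points lower from compound 1 to compound 3 (beyond the scatter). Both groups are six-membered aromatic rings with no net charge, so having such a ring at this position is not enough to hold the number up: which ring it is matters a great deal. Nothing available explains this large step.

This single pair changes both the count of hetero atoms in the ring and their arrangement, so it cannot show which of the two goes with the lower number. On these data alone, how a phenyl ring, which has no ring nitrogen, or pyridin-2-yl attached directly to the same nitrogen would compare on the shared core remains open.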